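The source may report more compounds than this note shows. Statements on the series, on what has been measured and on what is new or still open speak of the compounds shown alone.

Measured compounds:
Compound 1 `CSc1ccc(CN[C@@H]2C[C@H]3C[C@@H]([C@H]2C)C3(C)C)s1`; in an ADME assay on MDCK cells (Canis lupus familiaris) for cytotoxicity, read by microscopy, with a stated time of 48 h (a lower number here means that less compound is tolerated, a higher number that more compound is tolerated), compound 1 gives 25000 nM.
Compound 2 `C[C@H]1[C@H](NCc2ccc(Cl)s2)C[C@H]2C[C@@H]1C2(C)C`; in this assay compound 2 gives 25000 nM.

Compound 2 stands level with compound 1 at the digits shown. Within the data shown here, the single measured step, no change at the digits printed from compound 1 to compound 2 (within the scatter), put chloro in place of methylsulfanyl on an aromatic carbon and moved the reading not at all within the scatter.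

Compound 3 `C[C@H]1[C@H](NCc2nccs2)C[C@H]2C[C@@H]1C2(C)C` has not yet been measured in this assay. It differs from compound 2 by 1,3-thiazol-2-yl in place of 5-chlorothiophen-2-yl on a saturated chain carbon bound to an amine nitrogen. Among the measured compounds shown here, the one step that bears on it is no change at the digits printed from compound 1 to compound 2 (within the scatter), which changed the substituent on the same ring and left the value where it was. The present change exchanges the ring itself rather than a substituent on it, so that step is only a partial guide, but with both measured compounds level there is no sign of movement in either direction.

Compound 3 is therefore expected to give 25000 nM, with a range from 12500 nM to 50000 nM. The step this estimate means, no change at the digits printed from compound 2 to compound 3 (within the scatter), is expected to stay within the scatter.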

Compound 3, minimum cytotoxic concentration: > 100000 nM
Compound 3: only a limit was reported (the forecaster's own chance of this, stated with the estimate: 35%); at least 4.0-fold (0.60 log units) between middle value and limit.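

In this assay, exchanging the ring itself at this place, a saturated chain carbon bound to an amine nitrogen, gives an at least 4.0-fold higher number from compound 2 to compound 3 (0.60 log units; beyond the scatter), so the tolerated concentration does respond to what is attached here. The earlier step, no change at the digits printed from compound 1 to compound 2 (within the scatter), changed only the substituent on the ring and gave no sign of this, which means that the level reading of the first two compounds did not hold for every group at this place. The reading for compound 3 is a limit and not a number, so the step gives a minimum size and the full gap stays unknown: the limit of > 100000 nM in this assay, at which 1 of the 3 values shown sits.

The exchange removes the chlorine and brings in a ring nitrogen in one move, so the compounds shown do not tell whether the loss of the chlorine, the change of ring, or both together account for the step. A plain thiophen-2-yl would speak to the first of these and a 5-chloro-1,3-thiazol-2-yl to the second, and neither group stands among the compounds shown.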